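Ring Size at the Ether Tail of a Urea Series

The source may hold more compounds than are shown below. What is called first, only, known or untested is meant among the compounds shown, and "the series" means these compounds.

Three ureas built on one shared core have been measured in an assay on CHO cells for agonist activity at transient receptor potential cation channel subfamily V member 1 (Homo sapiens); a higher number here means that more compound is needed for the effect, a lower number that less compound is needed. Compound 1 `CC1CCN(c2nc(C(F)(F)F)ccc2CNC(=O)Nc2cccc3c(=O)[nH]ccc23)CC1` gives 9.59 nM. Compound 2 `CC(C)COc1nc(C(F)(F)F)ccc1CNC(=O)Nc1cccc2c(=O)[nH]ccc12` gives 78.7 nM, and compound 3 `O=C(NCc1ccc(C(F)(F)F)nc1OCC1CCC1)Nc1cccc2c(=O)[nH]ccc12` gives 63.2 nM. Compound 3 thus stands second highest of the three numbers, close to compound 2 and far from compound 1: the steps of an 8.2-fold higher number from compound 1 to compound 2 (0.91 log units; beyond the scatter) and a 6.6-fold higher number from compound 1 to compound 3 (0.82 log units; beyond the scatter) both lay beyond the scatter, while a 1.2-fold lower number from compound 2 to compound 3 (0.10 log units; within the scatter) stayed within it. Compound 4 `O=C(NCc1ccc(C(F)(F)F)nc1OCC1CCCC1)Nc1cccc2c(=O)[nH]ccc12` differs from compound 3 by a single change: cyclopentyl in place of cyclobutyl on a saturated chain carbon bound to an oxygen on an aromatic ring. The step that bears on this most directly is a 1.2-fold lower number from compound 2 to compound 3 (0.10 log units; within the scatter), where a change of the same kind at the same place left the number in this assay essentially unchanged. Going to the larger ring at that place is therefore expected to give no step beyond the scatter in this assay. Compound 4 is expected to give 60 nM, within a range from 30 nM to 120 nM. The step this estimate implies is a 1.1-fold lower number from compound 3 to compound 4 (0.02 log units; within the scatter).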

Compound 4, half-maximal effective concentration: 15.5 nM
For compound 4 the middle estimate is 3.9-fold (0.59 log units) above the measured one; the measured number lies below the stated range.
By their numbers in this assay, from the lowest: compounds 1 and 4 (each within the scatter of the next); then compounds 3 and 2 (each within the scatter of the next).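

At the saturated chain carbon bound to an oxygen on an aromatic ring, ring size turned out to matter in this assay: cyclopentyl in place of cyclobutyl gave a 4.1-fold lower number from compound 3 to compound 4 (0.61 log units; beyond the scatter) and a step beyond the scatter, although isopropyl and cyclobutyl had not been separated at this place. Cyclopentyl in place of isopropyl likewise gave a 5.1-fold lower number from compound 2 to compound 4 (0.71 log units; beyond the scatter), so the ether tails no longer form a single group in this assay. Cyclopentylmethoxy in place of 4-methylpiperidin-1-yl gave a 1.6-fold higher number from compound 1 to compound 4 (0.21 log units; within the scatter) and stayed within the scatter, which closes the gap that compound 2 and compound 3 had left to compound 1.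

Going by these compounds, whether cyclohexyl or a longer chain at the same place would continue this trend or reverse it remains open. Nothing available here explains the difference between the four-membered and five-membered rings.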